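The source may hold more compounds than are shown below. What is called first, only, known or untested is meant among the compounds shown, and "the series" means these compounds.

The measured compounds so far:

Compound 1, `Cc1ccccc1N1CCN(C(=S)SCc2ccc3nc(N)nc(N)c3c2)CC1`, which in a functional assay on MCF7 cells (Homo sapiens) for antiproliferative activity, read by MTT assay, with a stated time of 72 h (on this read-out higher numbers stand for weaker inhibition and lower numbers for stronger inhibition), gives 4230 nM.
Compound 2, `Cc1ccc(N2CCN(C(=S)SCc3ccc4nc(N)nc(N)c4c3)CC2)c(C)c1`, which in this assay gives 3120 nM.

Among the measured compounds shown here, compound 2 holds the lower of the two numbers, but the only other value lies just a 1.4-fold lower number from compound 1 to compound 2 (0.13 log units; within the scatter), a gap within the scatter, so the two compounds cannot be ordered against each other. Compound 3, `Nc1nc(N)c2cc(CSC(=S)N3CCN(c4ccccc4[N+](=O)[O-])CC3)ccc2n1`, has not yet been measured. It differs from compound 2 in one place: 2-nitrophenyl in place of 2,4-dimethylphenyl on an amine nitrogen in a ring. For the measured compounds named here, the single measured step, a 1.4-fold lower number from compound 1 to compound 2 (0.13 log units; within the scatter), concerns a change of another kind on the same aryl ring and was itself within the scatter; it offers no guidance on swapping the whole ring for one bearing a nitro group. Going by the values given here, with no step that bears directly on this exchange, and with the rest of the molecule unchanged, the expectation is for no movement beyond the scatter, with wide uncertainty in either direction. Compound 3 is therefore expected to give about 4000 nM in this assay, most likely between 1500 nM and 11000 nM, which corresponds to an expected step of a 1.3-fold higher number from compound 2 to compound 3 (0.11 log units; within the scatter).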

Compound 3, half-maximal inhibitory concentration: 4350 nM
Beside the measured number, compound 3's estimate is 1.1-fold (0.04 log units) below it; low and high end bracket the measured number.
By their numbers in this assay, from the lowest: compounds 2, 1 and 3 (each within the scatter of the next).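

In this assay, among the compounds shown here, the new step is the first to replace the aryl group on the amine nitrogen in the ring with one that carries different atoms, and both ways of reading it stay within the scatter: 2-nitrophenyl in place of 2,4-dimethylphenyl (a 1.4-fold higher number from compound 2 to compound 3 (0.14 log units; within the scatter)), and nitro in place of methyl on an aromatic carbon (a 1.0-fold higher number from compound 1 to compound 3 (0.01 log units; within the scatter)). The earlier pair had shown only that adding a methyl on this aryl ring left the number within the scatter, whereas these steps extend that to a group with oxygen and nitrogen atoms and with hydrogen-bond acceptors, which the methyl-bearing rings lack. Across these three compounds, then, this position shows no readable response to the changes tried, and no measured evidence here accounts for that.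

As far as these compounds go, whether an amine or a carboxylic acid on the same aromatic ring, or a longer chain in place of that ring, would move the number beyond the scatter remains open. From the compounds shown here alone, it also remains open whether this lack of separation would hold in other cell lines.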